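From methyl to hydrogen on the aromatic ring

The source may hold more compounds than are shown below. What is called first, only, known or untested is meant among the compounds shown, and "the series" means these compounds.

compound 1 `O=c1[nH]c(=O)n([C@H]2C[C@H](O)[C@@H](CO)O2)cc1COc1ccc(Br)cc1` gives 25000 nM
compound 2 `CCOc1ccc(OCc2cn([C@H]3C[C@H](O)[C@@H](CO)O3)c(=O)[nH]c2=O)cc1` gives 250000 nM
compound 3 `Cc1ccc(OCc2cn([C@H]3C[C@H](O)[C@@H](CO)O3)c(=O)[nH]c2=O)cc1` gives 250000 nM

All three numbers come from a functional assay on HeLa cells (Homo sapiens) for inhibition, with a stated time of 72 h; on this read-out higher numbers stand for weaker inhibition and lower numbers for stronger inhibition. Compound 3 shares the highest number of the three with compound 2. Compound 4 `O=c1[nH]c(=O)n([C@H]2C[C@H](O)[C@@H](CO)O2)cc1COc1ccccc1` differs from compound 3 by hydrogen in place of methyl on an aromatic carbon. The closest evidence is the swap between ethoxy and methyl, which moved nothing (no change at the digits printed from compound 2 to compound 3 (within the scatter)). Only bromo stood apart, in a modest step (a 10-fold higher number from compound 1 to compound 3 (1.00 log units; beyond the scatter)) that was matched by ethoxy (a 10-fold higher number from compound 1 to compound 2 (1.00 log units; beyond the scatter)). Hydrogen at this place is untested, so the expectation is loose. No step beyond the scatter is expected (a 1.3-fold lower number from compound 3 to compound 4 (0.10 log units; within the scatter)). For compound 4 the estimated value is 200000 nM (range 60000 nM to 500000 nM).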

Compound 4, half-maximal inhibitory concentration: 200000 nM
Compound 4: middle estimate and measured number agree at the digits printed; low and high end bracket the measured number.
By their numbers in this assay, from the lowest: compound 1; then compounds 4, 2 and 3 (each within the scatter of the next).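

Removing the methyl changes nothing beyond the scatter: this assay gives a 1.3-fold lower number from compound 3 to compound 4 (0.10 log units; within the scatter), and replacing ethoxy with hydrogen gives a 1.3-fold lower number from compound 2 to compound 4 (0.10 log units; within the scatter). With hydrogen now level with methyl and ethoxy, the unsubstituted ring marks the baseline, and bromo alone departs from it, as an 8.0-fold higher number from compound 1 to compound 4 (0.90 log units; beyond the scatter) shows. Nothing measured here explains why bromo differs.

From the compounds shown here alone, whether chloro or iodo at this place would match bromo remains open. So does the effect of an amine or a carboxylic acid there.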